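The source may report more compounds than this note shows. Statements on the series, on what has been measured and on what is new or still open speak of the compounds shown alone.

Of the compounds shown here, three that share one core have been measured in an assay on HEK293 cells for agonist activity at Toll-like receptor 8 (Homo sapiens), read by reporter gene assay; a higher number here means that more compound is needed for the effect, a lower number that less compound is needed. Compound 1 `CCCCCn1c(N)nc2ccccc21` carries a five-carbon chain and an amino group on that core, and in this assay compound 1 gives 3230 nM. Compound 2 `CCCCCn1c(N)nc2cc(C)ccc21` adds a methyl group to the aromatic ring and gives 4570 nM. Compound 3 `CCCCCn1c(N)nc2cccc(C)c21` places a methyl group on a different aromatic carbon and gives 6610 nM. Among these three numbers compound 1 has the lowest, so it needs the least compound for the effect; the step from compound 1 to compound 2 is a 1.4-fold higher number from compound 1 to compound 2 (0.15 log units; within the scatter), and the step from compound 1 to compound 3 is a 2.0-fold higher number from compound 1 to compound 3 (0.31 log units; beyond the scatter).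

Compound 4 `CCCCCn1c(N)nc2c(Br)cccc21` has not yet been measured. It differs from compound 1 in one place: bromo in place of hydrogen on an aromatic carbon. For the measured compounds named here, the two methyl steps are the only guides here. Both add a single small group to the same aromatic ring; one stayed within the scatter and the other rose modestly. A bromine atom added in the same way is therefore expected to give at most a modest rise in the number, and the expected step is a 1.5-fold higher number from compound 1 to compound 4 (0.19 log units; within the scatter). For compound 4 the estimate in this assay is 5000 nM, with a likely range from 2000 nM to 15000 nM.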

Compound 4, half-maximal effective concentration: "not active" (no number reported)
For compound 4 the study gives words and no number, so the estimate cannot be set against anything.
By their numbers in this assay, from the lowest: compounds 1, 2 and 3 (each within the scatter of the next, the first and the last beyond it).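

In this assay, for the compounds shown here, compound 4 is reported only in the words "not active", without a number, so no step from compound 1 to compound 4 can be read. No data shown here offer an explanation for this result. The compounds shown leave open whether a bromo group on another aromatic carbon, or a methyl group on this same carbon, would give a number.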